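Amino to Methyl Across Two Related Cores in Cytotoxicity

This account rests on a few compounds, and the source may have more. Where it says the series, first, only, none or still open, it means among the compounds named here.

Compound 1 `Cc1nnc(SCc2cc(=O)c3ccccc3o2)s1`: in a functional assay on SW480 cells (Homo sapiens) for cytotoxicity, read by MTT assay, with a stated time of 72 h (a higher number here means a weaker inhibitor, a lower number a stronger inhibitor), compound 1 gives > 25000 nM, a limit of the assay.
Compound 2 `Nc1nnc(SCc2cc(=O)c3ccccc3o2)s1`: compound 2 gives > 25000 nM, a limit of the assay.
Compound 3 `Nc1nnc(SCc2coc3ccccc3c2=O)s1`: compound 3 gives > 25000 nM, a limit of the assay.

Compound 2 and compound 3 are built from the same atoms joined differently; the difference between the two cores is not broken down here. From compound 2 to compound 1 the change is methyl in place of amino on an aromatic carbon, and the step that the two limits leave unreadable from compound 2 to compound 1 stays unreadable because of the limit of > 25000 nM in this assay, at which 3 of the 3 values shown sit. Compound 4 `Cc1nnc(SCc2coc3ccccc3c2=O)s1` is not yet measured; it carries the same change on the core of compound 3, (methyl in place of amino on an aromatic carbon). The expectation rests on compound 3 at its limit > 25000 nM and on the pair compound 2 and compound 1, both at the limit. Compound 4 is therefore expected to stay at a limit, with an expected step that the limit leaves unreadable from compound 3 to compound 4. The estimate for compound 4 is 50000 nM, expected between 20000 nM and 200000 nM.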

Compound 4, half-maximal inhibitory concentration: 1000 nM
Beside the measured number, compound 4's estimate is 50-fold (1.70 log units) above it; measured number below the stated range.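

In this assay, methyl in place of amino on an aromatic carbon gives an at least 25-fold lower number from compound 3 to compound 4 (1.39 log units; beyond the scatter), so on the core of compound 3 this single change has a large effect. The same change on the core of compound 2 cannot be read, since compound 2 and compound 1 both sit at a limit of the assay: the limit of > 25000 nM in this assay, at which 3 of the 4 values shown sit. The step therefore rests on one core alone, and it does not show whether a gain of similar size exists on the core of compound 1.

The compounds shown leave open how an ethyl group, a longer chain or a carboxylic acid in place of the methyl would read on the core of compound 4. They also leave open whether the effect of the methyl extends to any further core.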